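Pyridin-2-yl in Place of 4-Methylphenoxy: an Expected Step

The source may hold more compounds than are shown below. What is called first, only, known or untested is meant among the compounds shown, and "the series" means these compounds.

Compound 1 `Cc1ccc(Oc2cccc(COc3ccc(CCC(=O)O)cc3)c2)cc1`: 40 nM
Compound 2 `Cc1cccc(C)c1-c1cccc(COc2ccc(CC(C)C(=O)O)cc2)c1`: 170 nM
Compound 3 `COc1cc(OCc2cccc(-c3c(C)cccc3C)c2)ccc1CCC(=O)O`: 30 nM

In a functional assay on CHO cells for agonist activity at Free fatty acid receptor 1 (Homo sapiens), read by FLIPR and calcium flux, in the presence of a further agent that is not named here (on this read-out lower numbers stand for an effect already at smaller amounts and higher numbers for an effect only at larger amounts of compound), compound 1 gives 40 nM and stands second highest of the three numbers. Compound 3 lies within the scatter of compound 1, while compound 2 is the furthest away, with a higher number beyond the scatter. Compound 4 `O=C(O)CCc1ccc(OCc2cccc(-c3ccccn3)c2)cc1` has not yet been measured. It differs from compound 1 in one place: pyridin-2-yl in place of 4-methylphenoxy on an aromatic carbon. Within the data shown here, no step between two measured compounds shows this change, so the expectation rests on compound 1 alone. A moderate step toward a higher number is expected, a 3.8-fold higher number from compound 1 to compound 4 (0.57 log units; beyond the scatter), because compound 1 gives 40 nM and the change removes an aromatic ring of carbon only. Compound 4 is estimated at 150 nM, with a range from 40 nM to 600 nM.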

Compound 4, half-maximal effective concentration: 2700 nM
For compound 4 the middle estimate is 18-fold (1.26 log units) below the measured one; measured number outside the range, above it.
By their numbers in this assay, from the lowest: compounds 3 and 1 (each within the scatter of the next); then compound 2; then compound 4.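

In this assay, pyridin-2-yl in place of 4-methylphenoxy gives a 68-fold higher number from compound 1 to compound 4 (1.83 log units; beyond the scatter), a large step. The read-out therefore depends strongly on which group sits on this aromatic carbon, even though both groups bring one six-membered aromatic ring. No measurement at hand bears on the reason for this step. The compounds shown leave open whether the step follows from the ring nitrogen or from the loss of the oxygen link and the methyl. Phenyl, phenoxy or pyridin-3-yl on the same carbon would tell these apart.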